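Ethoxy for methyl on the aryl group of compound 1

A few compounds are considered here, and "the series" means these few. Any claim that something is new, unique, unknown or untested is made for them only; others in the source may bear on it.

Compound 1 `COc1cc(-n2ncnc2-c2ccc(C)cc2)cc(OC)c1OC` gives 90 nM in a functional assay on HL-60 cells (Homo sapiens) for antiproliferative activity, read by MTT assay, with a stated time of 72 h (on this read-out higher numbers stand for weaker inhibition and lower numbers for stronger inhibition), the only number shown in this set. Compound 2 `COc1cc(-n2ncnc2-c2cccc(Cl)c2)cc(OC)c1OC` sits at the limit > 10000 nM in this assay, a limit rather than a number (the limit of > 10000 nM in this assay, at which 1 of the 2 values shown sits). Going by the values given here, the single measured step, an at least 110-fold higher number from compound 1 to compound 2 (2.04 log units; beyond the scatter), concerns a different part of the molecule, so it bears only loosely on compound 3 `CCOc1ccc(-c2ncnn2-c2cc(OC)c(OC)c(OC)c2)cc1`, which differs from compound 1 by ethoxy in place of methyl on an aromatic carbon. Among the compounds with values here, no measured step covers this change. For compound 3 a step within the scatter, or slightly upward, is expected, a 1.7-fold higher number from compound 1 to compound 3 (0.22 log units; within the scatter). Compound 3 is therefore estimated at 150 nM, between 40 nM and 600 nM.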

Compound 3, half-maximal inhibitory concentration: 20 nM
Beside the measured number, compound 3's estimate is 7.5-fold (0.88 log units) above it, and the stated range ends above it.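

In this assay, the aromatic carbon para to a large group accepts a group larger than methyl with no loss: ethoxy in place of methyl gives a 4.5-fold lower number from compound 1 to compound 3 (0.65 log units; beyond the scatter). Going by these compounds alone, the earlier step concerned 3-chlorophenyl in place of 4-methylphenyl, so only this step reads this position alone. Nothing shown bears on why the number falls.

As far as these compounds go, whether the gain follows the added oxygen or the longer chain stays open, and methoxy and propoxy at this position would separate the two. From the compounds shown here alone, how an amine or a carboxylic acid would read there also remains open.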